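A few compounds are considered here, and "the series" means these few. Any claim that something is new, unique, unknown or untested is made for them only; others in the source may bear on it.

Measured compounds:
compound 1 `CCCCCCCCc1ccc(NC(=O)Nc2c(C(C)C)cccc2C(C)C)cc1` — 11 nM in an assay on isolated protein for inhibition of acyl-CoA:cholesterol acyltransferase (Oryctolagus cuniculus); on this read-out higher numbers stand for weaker inhibition and lower numbers for stronger inhibition
compound 2 `CCCc1ccc(NC(=O)Nc2c(C(C)C)cccc2C(C)C)cc1` — in this assay compound 2 gives 38 nM
compound 3 `CC(C)c1cccc(C(C)C)c1NC(=O)Nc1ccc(C(C)(C)C)cc1` — in this assay compound 3 gives 168 nM

Of these three, compound 1 has the lowest number, so in this assay it is the strongest inhibitor shown; its nearest neighbour is compound 2 with a 3.5-fold higher number from compound 1 to compound 2 (0.54 log units; beyond the scatter), and the furthest is compound 3 with a 15-fold higher number from compound 1 to compound 3 (1.18 log units; beyond the scatter). The unmeasured compound 4 `Cc1ccc(NC(=O)Nc2c(C(C)C)cccc2C(C)C)cc1` shares the core of compound 1 and differs from it in one place: hydrogen in place of heptyl on a saturated chain carbon bound to an aromatic carbon.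

Going by the values given here, two measured steps bear on this. Taking away part of the same chain gave a 3.5-fold higher number from compound 1 to compound 2 (0.54 log units; beyond the scatter); a short branched group instead of the chain gave a 4.4-fold higher number from compound 2 to compound 3 (0.65 log units; beyond the scatter). Each shortening of the chain so far raised the number beyond the scatter, and the change to compound 4 removes more of the chain than the change to compound 2 did. A step in this assay that is at least as large as that one, toward weaker inhibition, is therefore expected, roughly a 14-fold higher number from compound 1 to compound 4 (1.13 log units; beyond the scatter). Compound 4 is estimated at 150 nM, in the range 40 nM to 600 nM.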

Compound 4, half-maximal inhibitory concentration: 250 nM
The estimate for compound 4 lay 1.7-fold (0.22 log units) below the measured number, and the stated range covers the measured number.
By their numbers in this assay, from the lowest: compound 1; then compound 2; then compounds 3 and 4 (each within the scatter of the next).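

In this assay, cutting the chain on the aromatic carbon from octyl to methyl gives a 23-fold higher number from compound 1 to compound 4 (1.36 log units; beyond the scatter). Going from propyl to methyl alone gives a 6.6-fold higher number from compound 2 to compound 4 (0.82 log units; beyond the scatter). The size of the group alone does not set the number, however: tert-butyl and methyl cannot be told apart, with a 1.5-fold higher number from compound 3 to compound 4 (0.17 log units; within the scatter), although the propyl of compound 2 gives a clearly lower number than either. No measurement shown here accounts for these differences.

The compounds shown leave open whether a longer chain, such as dodecyl, would lower the number further or whether the gain ends near octyl. They also leave open how an amine or a carboxylic acid at the end of the chain would fare.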